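Extending the thioether chain on the shared core

This account rests on a few compounds, and the source may have more. Where it says the series, first, only, none or still open, it means among the compounds named here.

Measured compounds:
Compound 1, `CCCCCOc1nc(N)c2nc(O)n(Cc3ccccc3)c2n1`: 0.3 mg/kg
Compound 2, `CCCC[S+]([O-])c1nc(N)c2nc(O)n(Cc3ccccc3)c2n1`: 1 mg/kg
Compound 3, `CCCSc1nc(N)c2nc(O)n(Cc3ccccc3)c2n1`: 0.1 mg/kg

In a functional assay on the whole organism for activation, with Mus musculus as the target (a lower number here means that less compound is needed, a higher number that more compound is needed for the effect), compound 3 gives the lowest number of the three. From compound 1 the step to it is a 3.0-fold lower number from compound 1 to compound 3 (0.48 log units; beyond the scatter), and from compound 2 it is a 10-fold lower number from compound 2 to compound 3 (1.00 log units; beyond the scatter), both beyond the scatter, so compound 3 stands as the most potent of the measured set. The remaining pair shows a 3.3-fold higher number from compound 1 to compound 2 (0.52 log units; beyond the scatter).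

Compound 4, `CCCCSc1nc(N)c2nc(O)n(Cc3ccccc3)c2n1`, has yet to be measured. It differs from compound 3 by methyl in place of hydrogen on a saturated chain carbon, three bonds along the chain from a sulfur.

Among the measured compounds shown here, none of the measured steps is a plain lengthening of a chain by one carbon: each changes the atom joined to the aromatic carbon as well as the chain. The step from compound 1 to compound 3 shortens the chain while swapping oxygen for sulfur, and it is modest, so the chain length alone is not shown to move the number far. For the measured compounds named here, with no direct precedent, compound 4 is expected to stay close to compound 3, with the step of no change at the digits printed from compound 3 to compound 4 (within the scatter) estimated to fall within the scatter in either direction.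

Compound 4 is therefore estimated at 0.1 mg/kg, with a range from 0.03 mg/kg to 0.3 mg/kg.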

Compound 4, minimum effective dose: 0.3 mg/kg
Compound 4: the middle estimate sits 3.0-fold (0.48 log units) below what was measured; the range from low to high includes it.
By their numbers in this assay, from the lowest: compound 3; then compounds 1 and 4 (each within the scatter of the next); then compound 2.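

In this assay, among the compounds shown here, the propyl to butyl change is the first plain lengthening of the thioether chain, and a 3.0-fold higher number from compound 3 to compound 4 (0.48 log units; beyond the scatter) shows that the number responds to this single added methyl with the sulfur held in place. For the compounds shown here, with the butyl chain kept, removing the oxygen on the sulfur gives a 3.3-fold lower number from compound 2 to compound 4 (0.52 log units; beyond the scatter) and so separates that change from any change in chain length, which no earlier step could do. Butylsulfanyl in place of pentyloxy gives no change at the digits printed from compound 1 to compound 4 (within the scatter) and so, of the steps at this position, is the only one that leaves the number within the scatter.

Nothing given here explains these differences. With only the propyl and butyl thioethers to compare, the compounds shown leave open whether a shorter ethylsulfanyl or a longer pentylsulfanyl chain would follow the same direction, and how an amine on the same aromatic carbon would read.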